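The compounds below may be only part of what the source reports. "The series", "measured", "known", "first", "only" and "open" are said of these compounds alone.

Compound 1 `O=Cc1cn(Cc2ccc(Cl)cc2Cl)c2ccccc12`: > 31600 nM
Compound 2 `O=Cc1cn(Cc2ccc(Cl)cc2)c2ccc(F)cc12`: > 31600 nM

Both compounds were tested in an ADME assay on T29 cells (Homo sapiens) for cytotoxicity, read by sulforhodamine B assay, with a stated time of 3 days (on this read-out higher numbers stand for weaker inhibition and lower numbers for stronger inhibition), and neither gave a number. Compound 2 stands at > 31600 nM, which is a limit of the assay and not a measured value. Compound 1 gives > 31600 nM, which is likewise a limit. The whole record so far is therefore (the limit of > 31600 nM in this assay, at which 2 of the 2 values shown sit).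

Compound 3 `O=Cc1cn(Cc2ccc(Cl)cc2)c2ccc(Cl)cc12` is still to be tested in this assay. It differs from compound 2 by a single exchange, chloro in place of fluoro on an aromatic carbon. Among the compounds with values here, no pair of measured compounds shows what a change of this kind does, so no step beyond the scatter is expected. The expected change is a number no higher from compound 2 to compound 3 (the limit leaves the size open), and another reading at the limit is the likeliest result. For compound 3 the estimate is 31600 nM, with an expected range from 15000 nM to 40000 nM.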

Compound 3, half-maximal inhibitory concentration: > 31600 nM
Compound 3 gave a limit, no number; the forecaster's own chance of this, stated with the estimate: 85%; the middle value lies on the limit itself.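

Compound 2 and compound 3 are both reported only as limits in this assay, so no step can be read between them. The compounds shown leave open whether any change to the shared core would yield a measured number, as all rest at one limit: the limit of > 31600 nM in this assay, at which 3 of the 3 values shown sit.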